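Benzyl-triazole variants in the shared diol-ether series

A few compounds are considered here, and "the series" means these few. Any claim that something is new, unique, unknown or untested is made for them only; others in the source may bear on it.

Measured compounds:
compound 1, `N#Cc1ccc(Cn2cc(C[C@H](O)COCCOC[C@@H](O)Cc3ccc(-c4ccccc4)cc3)nn2)cc1`: 8800 nM
compound 2, `CC1=C(CCCCCCCCCCn2cc(C[C@H](O)COCCOC[C@@H](O)Cc3ccc(-c4ccccc4)cc3)nn2)C(=O)c2ccccc2C1=O`: 3000 nM
compound 3, `COC1=C(C)C(=O)C(CCCCCCCCCCn2cc(C[C@H](O)COCCOC[C@@H](O)Cc3ccc(-c4ccccc4)cc3)nn2)=C(C)C1=O`: 4000 nM

In a functional assay on HCT-116 cells (Homo sapiens) for inhibition, read by MTT assay, with a stated time of 72 h (on this read-out lower numbers stand for stronger inhibition of growth and higher numbers for weaker inhibition of growth), compound 1 gives 8800 nM, the highest of the three numbers. Compound 3 gives 4000 nM, a gap to compound 1 that lies beyond the scatter, and compound 2 gives 3000 nM, the furthest from compound 1, also beyond the scatter. No two of these compounds differ in only one place, so no single step between measured compounds is available.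

The unmeasured compound 4, `O[C@H](COCCOC[C@@H](O)Cc1cn(Cc2ccc(C(F)(F)F)cc2)nn1)Cc1ccc(-c2ccccc2)cc1`, keeps the shared core of compound 1 and differs from it in one place: trifluoromethyl in place of cyano on an aromatic carbon. Nothing in the measured set isolates the effect of a change at this position, since the compounds with lower numbers carry entirely different groups on the triazole nitrogen.

Going by the values given here, with no comparable step on record, the expectation for this assay is a step of no size beyond the scatter, with only a weak lean toward a lower number. Compound 4 is accordingly expected at 7000 nM, range 2500 nM to 20000 nM. The implied step from compound 1 to compound 4 is estimated as a 1.3-fold lower number from compound 1 to compound 4 (0.10 log units; within the scatter).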

Compound 4, concentration for 50% growth inhibition: 2500 nM
The estimate for compound 4 lay 2.8-fold (0.45 log units) above the measured number; the measured number falls inside the stated range.
By their numbers in this assay, from the lowest: compounds 4, 2 and 3 (each within the scatter of the next); then compound 1.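

In this assay, trifluoromethyl in place of cyano on the aromatic carbon gives a 3.5-fold lower number from compound 1 to compound 4 (0.55 log units; beyond the scatter), a step beyond the scatter. The other compounds differ from compound 1 by the whole group on the triazole nitrogen, so they could not show that this one aromatic carbon matters on its own; this pair shows that changing only the group there, with the rest of the 4-cyanobenzyl group and the shared core kept, is enough to move the number. No measurement in hand explains the step, which remains an observation from a single pair.

As far as these compounds go, with only nitrile and trifluoromethyl compared at this carbon, it remains open whether a chlorine, a methoxy group or a plain hydrogen there would fall nearer compound 1 at 8800 nM or compound 4 at 2500 nM. Also open, from the compounds shown here alone, is whether an amine or a carboxylic acid on the same carbon would retain the number of compound 4, and whether the same change would produce a similar step on a different part of the series.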